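This account rests on a few compounds, and the source may have more. Where it says the series, first, only, none or still open, it means among the compounds named here.

Compound 2 `Cc1nc(C(=O)N2CC3(CC3)C[C@H]2CNc2ccc(Cl)cn2)c(-c2ccccc2)s1` gives 8.3 in a functional assay on CHO cells for antagonist activity at Orexin/Hypocretin receptor type 1 (Homo sapiens), read by FLIPR and calcium flux; a higher number here means a more potent compound, by a factor of ten per unit of this negative logarithm, a lower number a less potent compound.
Compound 1 `Cc1ccnc(NC[C@@H]2CC3(CC3)CN2C(=O)c2nc(C)sc2-c2ccccc2)n1` gives 6.1 in this assay.

For the measured compounds named here, compound 2 stands at the top of these two numbers; the only other value, for compound 1, lies well below it, as a number 2.20 log units higher from compound 1 to compound 2 (beyond the scatter) shows. Compound 3 `Cc1nc(C(=O)N2CC3(CC3)C[C@H]2CNc2ccc(C(F)(F)F)cn2)c(-c2ccccc2)s1` differs from compound 2 only in one spot: trifluoromethyl in place of chloro on an aromatic carbon. Going by the values given here, no measured step covers this change; the single measured step, a number 2.20 log units higher from compound 1 to compound 2 (beyond the scatter), exchanges the whole ring on the amine nitrogen rather than one group on it. The expected step is therefore small, a number 0.10 log units higher from compound 2 to compound 3 (within the scatter), not beyond the scatter. Compound 3 is estimated at 8.4, between 7.8 and 9.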

Compound 3, negative logarithm of the antagonist equilibrium constant: 8.4
Estimate against measurement, compound 3: no gap at the digits printed; low and high end bracket the measured number.
By their numbers in this assay, from the lowest: compound 1; then compounds 2 and 3 (each within the scatter of the next).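

In this assay, the aromatic carbon two atoms from the ring nitrogen accepts trifluoromethyl as well as chloro, with a number 0.10 log units higher from compound 2 to compound 3 (within the scatter), although the group entering is larger by heavy-atom count. The high potency therefore does not depend on chloro alone, and 5-(trifluoromethyl)pyridin-2-yl also far outperforms 4-methylpyrimidin-2-yl, with a number 2.30 log units higher from compound 1 to compound 3 (beyond the scatter). No supporting measurement is available to explain these results. Still open, going by these compounds, is whether a methoxy group or an amine on that same carbon would keep the number this high.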